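Aromatic methyl step in the imidazoline aryl ether series

The compounds below may be only part of what the source reports. "The series", "measured", "known", "first", "only" and "open" are said of these compounds alone.

Compound 1 `Cc1cc(C)c(OC(C)C2=NCCN2)c(C)c1` and compound 2 `Cc1ccc(OC(C)C2=NCCN2)c(C)c1` share a core and differ only in that compound 1 carries an extra methyl group. In a physicochemical assay for lipophilicity (on this read-out higher numbers stand for higher lipophilicity and lower numbers for lower lipophilicity), compound 1 gives 5 and compound 2 gives 4.35. The difference between them is methyl in place of hydrogen on an aromatic carbon. Its effect is a number 0.65 log units higher from compound 2 to compound 1 (beyond the scatter).

Compound 3 `CCOC(=O)Nc1cccc(OC(C)C2=NCCN2)c1C` gives 3.27 in this assay, the lowest of the three numbers measured; compound 2 stands nearest to it and compound 1 furthest, both beyond the scatter. How the core of compound 3 differs from that of compound 2 is not broken down here.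

Compound 4 `CCOC(=O)Nc1ccc(C)c(OC(C)C2=NCCN2)c1C` is not yet measured. It differs from compound 3 by methyl in place of hydrogen on an aromatic carbon. This is the same kind of change as that from compound 2 to compound 1, but the surroundings are not identical: in compound 1 the new methyl stands meta to two methyl groups, whereas in compound 4 it stands meta to a methyl group and para to a (ethoxycarbonyl)amino group.

For compound 4 the expectation is a step of a number 0.58 log units higher from compound 3 to compound 4 (beyond the scatter) in this assay, resting on the single measured occurrence of this kind of change, the step from compound 2 to compound 1, which was a number 0.65 log units higher from compound 2 to compound 1 (beyond the scatter). Because compound 3 gives 3.27, compound 4 is estimated at 3.85, with a likely range from 3.45 to 4.25. The range is kept wide because the change rests on one pair only and the surroundings differ.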

Compound 4, partition coefficient: 4.4
Estimate against measurement, compound 4: 0.55 log units below; the whole stated range lies below it.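

In this assay, methyl in place of hydrogen on an aromatic carbon now has two readings, a number 0.65 log units higher from compound 2 to compound 1 (beyond the scatter) and a number 1.13 log units higher from compound 3 to compound 4 (beyond the scatter), and both run the same way, so the direction of the step carries from one core to the other in these two pairs, while its size is modest in the first pair and large in the second. Two pairs give no typical size for this change, and they do not separate the place of the new methyl, para to a (ethoxycarbonyl)amino group in compound 4, from the other differences between the two cores. Nothing available bears on why the two steps differ in size.

The compounds shown leave open whether the step would hold with an amine or a carboxylic acid in place of the (ethoxycarbonyl)amino group, and whether a longer chain such as ethyl on the same aromatic carbon would follow methyl. They also leave open whether the same change on another aromatic carbon of the core of compound 3 would read like either step.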